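Swapping the aryl substituent: from pyrazole to phenol

The compounds below may be only part of what the source reports. "The series", "measured", "known", "first", "only" and "open" are said of these compounds alone.

Compound 2 `CCn1cc(-c2cc(C(O)(C(F)(F)F)C(F)(F)F)cnc2N2CCN(S(=O)(=O)c3ccc(N)nc3)CC2)cn1` gives 20 mL.min-1.g-1 in an ADME assay (liver) for metabolic stability, with Liver microsome (Homo sapiens) as the target, using microsomes and NADPH, with a stated time of 30 min, tested at 1 uM; on this read-out higher numbers stand for fast clearance and lower numbers for slow clearance; compound 1 `COCC#Cc1cc(C(O)(C(F)(F)F)C(F)(F)F)cnc1N1CCN(S(=O)(=O)c2ccc(N)nc2)CC1` gives 15 mL.min-1.g-1, and the two numbers lie within the scatter of each other. Compound 3 `Nc1ccc(S(=O)(=O)N2CCN(c3ncc(C(O)(C(F)(F)F)C(F)(F)F)cc3-c3ccccc3O)CC2)cn1` carries 2-hydroxyphenyl in place of 1-ethyl-1H-pyrazol-4-yl on an aromatic carbon. Among the compounds with values here, the one step measured at this position, a 1.3-fold higher number from compound 1 to compound 2 (0.12 log units; within the scatter), changed little, so a similar exchange is expected to move the number only modestly, if at all. For compound 3 the estimate is 25 mL.min-1.g-1, with a range from 11 mL.min-1.g-1 to 55 mL.min-1.g-1, which means an expected step of a 1.3-fold higher number from compound 2 to compound 3 (0.10 log units; within the scatter) that may not exceed the scatter.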

Compound 3, intrinsic clearance in microsomes: 22 mL.min-1.g-1
Beside the measured number, compound 3's estimate is 1.1-fold (0.06 log units) above it, within the range that was stated.
By their numbers in this assay, from the lowest: compounds 1, 2 and 3 (each within the scatter of the next).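

Within the data shown here, at this position, ortho to a large group, 2-hydroxyphenyl is the first six-membered aromatic ring of carbon only and the first group carrying a hydrogen-bond donor, yet this assay shows no readable difference from 1-ethyl-1H-pyrazol-4-yl (a 1.1-fold higher number from compound 2 to compound 3 (0.04 log units; within the scatter)). Nor does it separate 2-hydroxyphenyl from 3-methoxyprop-1-yn-1-yl (a 1.5-fold higher number from compound 1 to compound 3 (0.17 log units; within the scatter)), so all three groups remain within the scatter along these steps. No available evidence bears on this result.

The compounds shown leave open whether unsubstituted phenyl, an amine or a carboxylic acid on this carbon would give a number beyond the scatter.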